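Amide-aryl substituent notes: methoxy to methoxycarbonyl

This account rests on a few compounds, and the source may have more. Where it says the series, first, only, none or still open, it means among the compounds named here.

Measured in an in vitro assay on HEK ts201 cells for negative allosteric modulation of Neuronal acetylcholine receptor; alpha3/beta4 (Homo sapiens), read by fluorescence and calcium flux, with a stated time of 1.5 s; a higher number here means a weaker inhibitor, a lower number a stronger inhibitor:
compound 1 `O=C(CN1CCN(S(=O)(=O)c2ccccc2F)CC1)Nc1ccccc1F` gives 99800 nM
compound 2 `O=C(CN1CCN(S(=O)(=O)c2ccccc2F)CC1)Nc1ccc(F)cc1` gives 13600 nM
compound 3 `COc1ccc(NC(=O)CN2CCN(S(=O)(=O)c3ccccc3F)CC2)cc1` gives 19100 nM

Compound 3 stands second highest of the three numbers in this assay. Its nearest neighbour is compound 2, separated by a 1.4-fold higher number from compound 2 to compound 3 (0.15 log units; within the scatter). Its furthest is compound 1, separated by a 5.2-fold lower number from compound 1 to compound 3 (0.72 log units; beyond the scatter); the companion move a 7.3-fold lower number from compound 1 to compound 2 (0.87 log units; beyond the scatter) is of similar size. The two steps beyond the scatter both concern where the substituent sits on the amide-side ring, not which substituent it is.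

Compound 4 `COC(=O)c1ccc(NC(=O)CN2CCN(S(=O)(=O)c3ccccc3F)CC2)cc1` is not yet measured. It differs from compound 3 by methoxycarbonyl in place of methoxy on an aromatic carbon. Going by the values given here, the one measured step that bears on a change of group at this place is a 1.4-fold higher number from compound 2 to compound 3 (0.15 log units; within the scatter), which lay within the scatter. Among the compounds with values here, no measured compound carries a methoxycarbonyl or any group of comparable size there, so the expectation rests on that single step alone and is held loosely. The step from compound 3 is expected to be a 1.0-fold lower number from compound 3 to compound 4 (0.00 log units; within the scatter), that is, none beyond the scatter in either direction. Compound 4 is therefore estimated at 19000 nM in this assay, with a range of 7000 nM to 55000 nM.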

Compound 4, half-maximal inhibitory concentration: 11200 nM
Compound 4: middle estimate off by 1.7-fold (0.23 log units), on the high side, and the stated range covers the measured number.
By their numbers in this assay, from the lowest: compounds 4, 2 and 3 (each within the scatter of the next); then compound 1.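

In this assay, methoxycarbonyl, the largest group yet placed para to a large group, leaves the number within the scatter of the smaller groups: the comparison with methoxy reads a 1.7-fold lower number from compound 3 to compound 4 (0.23 log units; within the scatter) and the comparison with fluoro reads a 1.2-fold lower number from compound 2 to compound 4 (0.08 log units; within the scatter) and so compounds 2, 3 and 4 cannot be ordered. At this place, therefore, a change from fluoro through methoxy to methoxycarbonyl, which adds heavy atoms, a carbonyl and a hydrogen-bond acceptor, has not yet produced a step beyond the scatter, and the third substituent here also stands clear of compound 1, with an 8.9-fold lower number from compound 1 to compound 4 (0.95 log units; beyond the scatter) as the step, although that step changes both the group and where it sits. No supporting measurement is available to explain why these three groups cannot be separated here.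

Still open, going by these compounds, is whether a carboxylic acid, a primary amide or an amine at this same place would stay within the scatter of compounds 2, 3 and 4 or break from them. Also open, on these data alone, is whether methoxycarbonyl, placed where compound 1 carries its amide-side fluoro, would reproduce the high number of compound 1.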